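From chloro to methoxy: estimating compound 4

The source may report more compounds than this note shows. Statements on the series, on what has been measured and on what is new or still open speak of the compounds shown alone.

Of the compounds shown here, three built on a shared core have been tested in a functional assay on A-375 cells (Homo sapiens) for antiproliferative activity, read by MTT assay, with a stated time of 72 h; a lower number here means a stronger inhibitor, a higher number a weaker inhibitor. Compound 1 `COc1ncc(-c2ccc3c(c2)N(C2CCCCC2)C(=O)CO3)cc1NS(=O)(=O)c1ccc(F)cc1` reads > 40000 nM, which is a limit of the assay and not a number. Compound 2 `COc1ncc(-c2ccc3c(c2)N(c2ccccc2)C(=O)CO3)cc1NS(=O)(=O)c1ccc(F)cc1` gives 15200 nM. Going by the values given here, the one measured step, an at least 2.6-fold lower number from compound 1 to compound 2 (0.42 log units; beyond the scatter), comes with phenyl in place of cyclohexyl on an amide-type nitrogen in a ring. Compound 3 `O=C1COc2ccc(-c3cnc(Cl)c(NS(=O)(=O)c4ccc(F)cc4)c3)cc2N1c1ccc(Cl)cc1` gives 30600 nM, within the usual scatter of the value for compound 2.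

Compound 4 `COc1ncc(-c2ccc3c(c2)N(c2ccc(Cl)cc2)C(=O)CO3)cc1NS(=O)(=O)c1ccc(F)cc1` differs from compound 3 in one place: methoxy in place of chloro on an aromatic carbon. In words, methoxy takes the place of chloro on an aromatic carbon. The measured step lies at another place in the molecule, so it offers no direct guide to this swap. The nearest hint comes from compound 2, which already carries the methoxy and gives 15200 nM, although it also lacks the chloro on its phenyl. Its value and that of compound 3 do not separate beyond the scatter, so no large step is expected in this assay. At most a slightly lower number is expected, and the estimate is a 1.5-fold lower number from compound 3 to compound 4 (0.18 log units; within the scatter). For compound 4 the estimated value is 20000 nM, with an expected range of 9000 nM to 40000 nM.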

Compound 4, half-maximal inhibitory concentration: 24100 nM
Beside the measured number, compound 4's estimate is 1.2-fold (0.08 log units) below it; the range from low to high includes it.
By their numbers in this assay, from the lowest: compounds 2, 4 and 3 (each within the scatter of the next). At a limit, above all of these: compound 1.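

In this assay, the carbon next to the ring nitrogen now has a direct swap, and a 1.3-fold lower number from compound 3 to compound 4 (0.10 log units; within the scatter) shows that methoxy and chloro at this position cannot be told apart here. A second place on the molecule behaves the same way, since adding chloro to the phenyl on the amide-type nitrogen gives a 1.6-fold higher number from compound 2 to compound 4 (0.20 log units; within the scatter), so neither single change moves the number beyond the scatter. The step for 4-chlorophenyl in place of cyclohexyl, an at least 1.6-fold lower number from compound 1 to compound 4 (0.22 log units; that floor lies within the scatter), can be read only as a floor, as the reading of compound 1 is a limit of the assay and not a number: the limit of > 40000 nM in this assay, at which 1 of the 4 values shown sits.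

Still open, on these data alone, is whether a quite different group at the position next to the ring nitrogen, such as an amine, a carboxylic acid or a longer chain like butoxy, would shift the number beyond the scatter. Also open, as far as these compounds go, is whether methoxy and chloro at this position would still read alike with a plain phenyl on the amide-type nitrogen, or with an amine on that phenyl in place of chloro.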